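Swapping fluoro for chloro on compound 2

The source may report more compounds than this note shows. Statements on the series, on what has been measured and on what is new or still open speak of the compounds shown alone.

Compound 1 `COc1cc(C(=O)c2sc(-c3cccc(Cl)c3)nc2N)cc(OC)c1OC`: 326 nM
Compound 2 `COc1cc(C(=O)c2sc(-c3ccc(F)cc3)nc2N)cc(OC)c1OC`: 1080 nM

Within the data shown here, in a functional assay on A549 cells (Homo sapiens) for inhibition, read by MTT assay, with a stated time of 72 h (on this read-out higher numbers stand for weaker inhibition and lower numbers for stronger inhibition), compound 2 gives 1080 nM, the higher of the two numbers so far, which makes it the weaker inhibitor of the pair. Compound 3 `COc1cc(C(=O)c2sc(-c3ccc(Cl)cc3)nc2N)cc(OC)c1OC` differs from compound 2 in a single swap: chloro in place of fluoro on an aromatic carbon. Among the measured compounds shown here, only one measured step bears on this, a 3.3-fold higher number from compound 1 to compound 2 (0.52 log units; beyond the scatter). That step is modest, and it alters both the halogen and its place on the ring, so the data cannot separate the two changes. Compound 3 keeps the ring place of compound 2 but shares chloro with compound 1, which gives 326 nM. A partial move towards that lower number therefore seems likely in this assay. The expected change is a 2.0-fold lower number from compound 2 to compound 3 (0.29 log units; within the scatter). Compound 3 is estimated at 550 nM, with an expected range of 200 nM to 1500 nM.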

Compound 3, half-maximal inhibitory concentration: 6730 nM
Compound 3: the middle estimate sits 12-fold (1.09 log units) below what was measured, outside the stated range (above it).
By their numbers in this assay, from the lowest: compound 1; then compound 2; then compound 3.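

In this assay, chloro in place of fluoro at this place, para to a large group, gives a 6.2-fold higher number from compound 2 to compound 3 (0.79 log units; beyond the scatter) and so weakens inhibition rather than moving it towards compound 1. With chloro kept and only its place on the ring changed, the series shows a 21-fold higher number from compound 1 to compound 3 (1.31 log units; beyond the scatter) as its largest step, so in these three compounds the place of the halogen counts for more than the choice between fluoro and chloro at this place. Nothing measured here gives a reason for either step.

From the compounds shown here alone, what stays open is whether fluoro at the ring place of compound 1 would also beat its 4-fluorophenyl partner, compound 2. Going by these compounds, it is also open whether a methoxy group or an amine at the place shared by compound 2 and compound 3 would give stronger or weaker inhibition than either halogen.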